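A Smaller Ring Replaces the Carboxypyridyl Group

A few compounds are considered here, and "the series" means these few. Any claim that something is new, unique, unknown or untested is made for them only; others in the source may bear on it.

Measured so far:
compound 1, `O=C(O)c1cc(-c2cnc(C(=O)CCc3ccc(-c4ccccc4)cc3)o2)ccn1`, 50 nM
compound 2, `O=C(O)c1cccc(-c2cnc(CCCc3ccc(-c4ccccc4)cc3)o2)n1`, 10000 nM
compound 3, `O=C(CCc1ccc(COc2ccccc2)cc1)c1ncco1`, 25 nM

In an assay for inhibition of Fatty-acid amide hydrolase 1 (Rattus norvegicus) (a higher number here means a weaker inhibitor, a lower number a stronger inhibitor), compound 1 gives 50 nM, the second highest of the three numbers. Compound 3 is nearest, and its number lies within the scatter of that for compound 1. Compound 2 stands far beyond the scatter with a much higher number; it lacks the carbonyl that compounds 1 and 3 share. Compound 4, `O=C(CCc1ccc(-c2ccccc2)cc1)c1ncc(-c2cccnc2)o1`, has not yet been measured. It differs from compound 1 in one place: pyridin-3-yl in place of 2-carboxypyridin-4-yl on an aromatic carbon. Within the data shown here, no measured pair shows this exact change. Compound 3, bare at this place, gives 25 nM. A modest step toward a lower number is therefore expected for compound 4, estimated as a 4.2-fold lower number from compound 1 to compound 4 (0.62 log units; beyond the scatter). Compound 4 is expected to give 12 nM, most likely between 3 nM and 50 nM.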

Compound 4, inhibition constant: 1.1 nM
For compound 4 the middle estimate is 11-fold (1.04 log units) above the measured one; the whole stated range lies above it.
By their numbers in this assay, from the lowest: compound 4; then compounds 3 and 1 (each within the scatter of the next); then compound 2.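

Replacing 2-carboxypyridin-4-yl with pyridin-3-yl on the aromatic carbon next to the ring oxygen makes a large difference in this assay (a 45-fold lower number from compound 1 to compound 4 (1.66 log units; beyond the scatter)). The carboxylic acid on this ring is therefore not needed for a low number in this series. No measurement shown gives a reason for the step.

Going by these compounds, the loss of the carboxylic acid and the change in how the pyridine ring is attached happen together, so their separate contributions remain unknown. On these data alone, how a plain phenyl ring or an amine on the pyridine would fare at this place also remains open.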